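Acetyl to dimethylamino on the pendant phenyl ring

The compounds below may be only part of what the source reports. "The series", "measured", "known", "first", "only" and "open" are said of these compounds alone.

Compound 1 `COc1cc(C)cc(-c2c(-c3ccnc(-c4ccc(C(C)=O)cc4)c3)cnn2CC#N)c1`: 21%
Compound 2 `COc1cc(C)cc(-c2nn(CC#N)cc2-c2ccc(-c3cccc(C(C)=O)c3)nc2)c1`: 13%
Compound 3 `Cc1cc(O)cc(-c2nn(CC#N)cc2-c2ccnc(-c3ccc(Oc4ccccc4)cc3)c2)c1`: -13%

In a functional assay on MDA-MB-231 cells (Homo sapiens) for cytotoxicity, read by sulforhodamine B assay, with a stated time of 48 h, tested at 1 uM (on this read-out lower numbers stand for a stronger effect and higher numbers for a weaker effect at the one concentration tested), compound 1 gives the highest of the three numbers. Compound 2 sits within the scatter of compound 1, while compound 3 lies beyond it, showing a clearly stronger effect at the single concentration tested.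

Compound 4 `COc1cc(C)cc(-c2c(-c3ccnc(-c4ccc(N(C)C)cc4)c3)cnn2CC#N)c1` differs from compound 1 in one place: dimethylamino in place of acetyl on an aromatic carbon. Within the data shown here, no pair of measured compounds shows this change, so its effect in this assay cannot be read from the data. A step of no size beyond the scatter is expected, in either direction, as a number 3 percentage points higher from compound 1 to compound 4 (within the scatter). Compound 4 is therefore estimated at 24%, within 0% to 48%.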

Compound 4, a percentage reported as activity, at one concentration (the size of the read-out at that concentration, not a potency): 17%
Compound 4: the middle estimate sits 7 percentage points above what was measured, within the range that was stated.
By their numbers in this assay, from the lowest: compound 3; then compounds 2, 4 and 1 (each within the scatter of the next).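

In this assay, among these compounds, the change from 4-acetylphenyl to 4-(dimethylamino)phenyl gives the first one-place comparison at this position, and it reads as a number 4 percentage points lower from compound 1 to compound 4 (within the scatter) at the one concentration tested. The read-out therefore does not separate acetyl from dimethylamino at this place on the core of compound 1. No measurement shown here offers an explanation for this result.

On these data alone, whether a primary amine, a carboxylic acid or a longer chain at this place would shift the number remains open. So does whether the same exchange would give a similar step on another core.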